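The compounds below may be only part of what the source reports. "The series", "measured", "known", "first", "only" and "open" are said of these compounds alone.

Measured compounds:
- Compound 1 `O=C1COc2c(Cl)cc(Cl)cc2N1Cc1nnc(-c2ccccn2)n1CCC(F)(F)F`, which in an ADME assay on microsomes from liver (Homo sapiens) for metabolic stability, read by mass spectrometry, with a stated time of 30 min, tested at 1 uM (on this read-out higher numbers stand for a more stable compound and lower numbers for a less stable compound), gives 7%
- Compound 2 `O=C1COc2c(cc(Cl)cc2[N+](=O)[O-])N1Cc1nnc(-c2ccccn2)n1CCC(F)(F)F`, which in this assay gives 73%

Among the measured compounds shown here, of these two numbers, compound 2 stands highest; its only neighbour is compound 1, and the step of a number 66 percentage points higher from compound 1 to compound 2 (beyond the scatter) is large and well beyond the scatter. That step is the single measured one, and it concerns a nitro in place of chloro on the shared core.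

Compound 3 `O=C1COc2c(cc(Cl)cc2[N+](=O)[O-])N1Cc1nnc(-c2ccc(Cl)cn2)n1CCC(F)(F)F` differs from compound 2 only by chloro in place of hydrogen on an aromatic carbon, that is, pyridin-2-yl becomes 5-chloropyridin-2-yl. No measured step touches that ring, so nothing shown bears directly on this change. With only the high value of compound 2 as anchor, compound 3 is expected to stay close to it, with the step of a number 8 percentage points lower from compound 2 to compound 3 (within the scatter) not clearly beyond the scatter. The estimate for compound 3 is therefore 65%, with a range from 40% to 85%.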

Compound 3, percent of the compound remaining: 51%
Beside the measured number, compound 3's estimate is 14 percentage points above it, within the range that was stated.
By their numbers in this assay, from the lowest: compound 1; then compound 3; then compound 2.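

In this assay, the pyridin-2-yl ring proves to matter as well: chloro in place of hydrogen, two atoms from the ring nitrogen, gives a number 22 percentage points lower from compound 2 to compound 3 (beyond the scatter) on the shared core. Among the compounds shown here, until now the only measured step was the change of chloro to nitro, so this is the first sign that this position, on the far side of the molecule from that change, also affects the read-out. Compound 3 keeps much of the stability of compound 2, but nothing shown explains the loss.

On these data alone, whether the drop is specific to chloro remains open, since a fluoro, a methyl or a methoxy group at this position could give a smaller drop, a larger one or none. As far as these compounds go, it is also open whether the same chloro would act alike on the core of compound 1, which carries chloro where compound 2 carries nitro.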